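The compounds below may be only part of what the source reports. "The series", "measured", "known", "first", "only" and "open" are said of these compounds alone.

Three cyanoaziridine ureas have been measured in a functional assay on RPMI-8226 cells (Homo sapiens) for inhibition; a higher number here means a weaker inhibitor, a lower number a stronger inhibitor. Compound 1 `CCCCNC(=O)N1CC1C#N` gives 17000 nM, the highest number of the three. Compound 2 `CCOC(=O)c1ccc(NC(=O)N2CC2C#N)cc1` gives 3000 nM and compound 3 `N#CC1CN1C(=O)Nc1ccc(Cl)cc1Cl` gives 4700 nM, both lower than the number for compound 1 by more than the usual scatter, so compound 1 is the weakest inhibitor of the set so far. Compound 4 `CCNC(=O)N1CC1C#N` differs from compound 1 in one place: hydrogen in place of ethyl on a saturated chain carbon, two bonds along the chain from an amide-type nitrogen. Going by the values given here, no measured pair shows this change directly. The shorter chain is expected to move the number by a 1.5-fold higher number from compound 1 to compound 4 (0.17 log units; within the scatter), a modest step toward weaker inhibition rather than none. Compound 4 is therefore expected to give about 25000 nM, within a range from 8000 nM to 80000 nM.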

Compound 4, half-maximal inhibitory concentration: 22000 nM
Estimate against measurement, compound 4: 1.1-fold (0.06 log units) above; the range from low to high includes it.
By their numbers in this assay, from the lowest: compounds 2 and 3 (each within the scatter of the next); then compounds 1 and 4 (each within the scatter of the next).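

Hydrogen in place of ethyl on a saturated chain carbon, two bonds along the chain from an amide-type nitrogen, gives a 1.3-fold higher number from compound 1 to compound 4 (0.11 log units; within the scatter) in this assay, so at this position the butyl and ethyl chains cannot be told apart. Going by these compounds alone, this is the first direct reading of chain length on the shared core, and it shows that this change alone does not separate the two compounds. No supporting measurement offers an explanation for this result. From the compounds shown here alone, whether a longer chain such as hexyl, or a chain ending in an amine or a carboxylic acid, would stand apart from these two remains open.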